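The source may report more compounds than this note shows. Statements on the series, on what has been measured and on what is new or still open speak of the compounds shown alone.

Four compounds share one core and differ only in the aryl group carried on the urea nitrogen. Compound 1 `COc1cc2ncnc(NCc3cccc(NC(=O)Nc4ccccc4C)c3)c2cc1OC` gives 21400 nM in a functional assay on A549 cells (Homo sapiens) for antiproliferative activity, read by MTT assay; on this read-out higher numbers stand for weaker inhibition and lower numbers for stronger inhibition. Compound 2 `COc1ccc(NC(=O)Nc2cccc(CNc3ncnc4cc(OC)c(OC)cc34)c2)cc1` gives 24500 nM in this assay, and the two numbers sit within the scatter of each other: a 1.1-fold higher number from compound 1 to compound 2 (0.06 log units; within the scatter). Compound 3 `COc1cc2ncnc(NCc3cccc(NC(=O)Nc4ccc([N+](=O)[O-])cc4)c3)c2cc1OC` stands apart. In this assay compound 3 gives only > 50000 nM, which is a limit of the assay and not a number. Two measured steps lead to it: an at least 2.3-fold higher number from compound 1 to compound 3 (0.36 log units; beyond the scatter), and an at least 2.0-fold higher number from compound 2 to compound 3 (0.30 log units; that floor lies within the scatter).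

Compound 4 `COc1cc2ncnc(NCc3cccc(NC(=O)Nc4cccc(C(F)(F)F)c4)c3)c2cc1OC` is the next step from compound 3, with 3-(trifluoromethyl)phenyl in place of 4-nitrophenyl on an amide-type nitrogen. The two steps that end at compound 3 both raised the number when 4-nitrophenyl entered, one of them beyond the scatter. Going away from 4-nitrophenyl, the number is therefore expected to fall back toward the values of compound 1 and compound 2, a step of an at least 1.7-fold lower number from compound 3 to compound 4 (0.25 log units; that floor lies within the scatter) in this assay. For compound 4 the estimate is 28000 nM, expected to lie between 10000 nM and 70000 nM.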

Compound 4, half-maximal inhibitory concentration: 35300 nM
Compound 4: the middle estimate sits 1.3-fold (0.10 log units) below what was measured, and the stated range covers the measured number.
By their numbers in this assay, from the lowest: compounds 1, 2 and 4 (each within the scatter of the next). At a limit, above all of these: compound 3.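

A third substituted phenyl group on this amide-type nitrogen gives a number that cannot be told apart from the first two in this assay: there is a 1.6-fold higher number from compound 1 to compound 4 (0.22 log units; within the scatter), and there is a 1.4-fold higher number from compound 2 to compound 4 (0.16 log units; within the scatter). Among the compounds shown, 2-methylphenyl, 4-methoxyphenyl and 3-(trifluoromethyl)phenyl therefore read alike, even though each carries a different group at a different place on the ring. The step away from 4-nitrophenyl, an at least 1.4-fold lower number from compound 3 to compound 4 (0.15 log units; that floor lies within the scatter), starts from a limit of the assay and not from a number: the limit of > 50000 nM in this assay, at which 1 of the 4 values shown sits.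

From the compounds shown here alone, whether 4-nitrophenyl truly stands apart from all three other groups stays open. Going by these compounds, what an amine or a carboxylic acid on the phenyl ring, or a longer chain in place of that ring, would do on this nitrogen also stays open.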